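Swapping the aryl group on the piperazine nitrogen

A few compounds are considered here, and "the series" means these few. Any claim that something is new, unique, unknown or untested is made for them only; others in the source may bear on it.

Compound 1 `Nc1scc(CN2CCN(c3cccc(C(F)(F)F)c3)CC2)c1C(=O)c1ccc(Cl)cc1`: -80%
Compound 2 `Nc1scc(CN2CCN(c3cccnc3)CC2)c1C(=O)c1ccc(Cl)cc1`: -23%
Compound 3 `Nc1scc(CN2CCN(c3ccc(F)c(F)c3)CC2)c1C(=O)c1ccc(Cl)cc1`: -87%

All three share one core and differ only in the group carried on the amine nitrogen of the six-membered ring with two nitrogens. The read-out is a functional assay on CHO cells with adenosine receptor A1 (Homo sapiens) as the target, read by cAMP accumulation and immunoassay, with a stated time of 6 min, tested at 10 uM; a lower number here means a stronger effect, a higher number a weaker effect of the compound at the concentration tested. Compound 3 carries a 3,4-difluorophenyl group there and gives -87%, the lowest of the three numbers; compound 1 sits close by, and a number 7 percentage points lower from compound 1 to compound 3 (within the scatter), while compound 2 lies far off, with a number 64 percentage points lower from compound 2 to compound 3 (beyond the scatter).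

Compound 4 `Nc1scc(CN2CCN(c3ccccc3Cl)CC2)c1C(=O)c1ccc(Cl)cc1` is the next step from compound 3. The change is 2-chlorophenyl in place of 3,4-difluorophenyl on an amine nitrogen in a ring. Both the group that leaves and the group that enters are a six-membered aromatic ring of carbon only, as are the groups in compound 1 and compound 3, which gave numbers within the scatter of one another. Among the compounds with values here, the only large steps recorded, a number 57 percentage points higher from compound 1 to compound 2 (beyond the scatter) and a number 64 percentage points lower from compound 2 to compound 3 (beyond the scatter), involve pyridin-3-yl, which is not part of this change. A step of modest size is therefore expected, a number 12 percentage points higher from compound 3 to compound 4 (beyond the scatter), plausibly within the scatter. Compound 4 is estimated at -75%, with a range from -95% to -45%.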

Compound 4, a percentage reported as activity, at one concentration (the size of the read-out at that concentration, not a potency): -18%
Beside the measured number, compound 4's estimate is 57 percentage points below it, outside the stated range (above it).
By their numbers in this assay, from the lowest: compounds 3 and 1 (each within the scatter of the next); then compounds 2 and 4 (each within the scatter of the next).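

Having a six-membered aromatic ring of carbon only on this nitrogen does not by itself give a low number in this assay, as 2-chlorophenyl shows against both 3,4-difluorophenyl (a number 69 percentage points higher from compound 3 to compound 4 (beyond the scatter)) and 3-(trifluoromethyl)phenyl (a number 62 percentage points higher from compound 1 to compound 4 (beyond the scatter)). Within the data shown here, until now pyridin-3-yl was the only group tied to a large step, but compound 4 now sits level with compound 2 (a number 5 percentage points higher from compound 2 to compound 4 (within the scatter)), even though 2-chlorophenyl has no ring nitrogen. Among these four compounds, then, the ring type alone does not sort the numbers, and nothing measured here explains the gap between the groups on carbon-only rings.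

Going by these compounds, what stays open is whether the chlorine itself or its place on the ring goes with the higher number, a question that a plain phenyl, 3-chlorophenyl or 4-chlorophenyl group on the same nitrogen would help to separate. Also open, on these data alone, is how a non-aromatic group there, such as a cyclohexyl ring or a short alkyl chain, would read in this assay on the shared core.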